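Swapping a sulfonyl aryl group on a serotonin-receptor ligand

The compounds below may be only part of what the source reports. "The series", "measured", "known", "first", "only" and "open" are said of these compounds alone.

Compound 1: `CCN1CCC(n2cc(S(=O)(=O)C3=C(Cl)NC4SC=CN34)c3cccnc32)C1`, 1.4 nM; compound 2: `O=S(=O)(c1cc(Cl)cc(Cl)c1)c1cn(C2CCCNC2)c2ncccc12`, 6.1 nM

Of the compounds shown here, two have been measured in an assay on HeLa cells for displacement of a labelled ligand from 5-hydroxytryptamine receptor 6 (Homo sapiens); a lower number here means a stronger inhibitor, a higher number a weaker inhibitor. Compound 1 gives 1.4 nM, and compound 2 gives 6.1 nM, the higher of the two numbers; the gap between them lies beyond the usual scatter. The two structures differ in more than one place, so no single change can be tied to that gap.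

Compound 3 is `O=S(=O)(C1=C(Cl)NC2SC=CN12)c1cn(C2CCCNC2)c2ncccc12`. It keeps the core of compound 2 and changes only the group on the sulfonyl sulfur: a group of 9 heavy atoms (5 carbon, 2 nitrogen, 1 sulfur, 1 chlorine; 2 five-membered non-aromatic rings with 2 hetero atoms each) in place of a group of 8 heavy atoms (6 carbon, 2 chlorine; one six-membered aromatic ring of carbon only), on a sulfonyl sulfur. The group that enters is the same one carried by compound 1, whose value of 1.4 nM is the lower of the two measured. On that basis a modest fall in this assay is expected, a 2.4-fold lower number from compound 2 to compound 3 (0.39 log units; beyond the scatter). Compound 3 is estimated at 2.5 nM, within a range of 0.8 nM to 8 nM.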

Compound 3, inhibition constant: 0.7 nM
Beside the measured number, compound 3's estimate is 3.6-fold (0.55 log units) above it; the measured number lies below the stated range.
By their numbers in this assay, from the lowest: compounds 3 and 1 (each within the scatter of the next); then compound 2.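

With the rest of compound 2 held fixed, putting the group carried by compound 1 in place of 3,5-dichlorophenyl on the sulfonyl sulfur gives an 8.7-fold lower number from compound 2 to compound 3 (0.94 log units; beyond the scatter) in this assay and so ties a change in this read-out to this one position, which the first two compounds, differing in more than one place, could not do. Piperidin-3-yl in place of 1-ethylpyrrolidin-3-yl on the aromatic nitrogen gives a 2.0-fold lower number from compound 1 to compound 3 (0.30 log units; within the scatter) and leaves these two compounds indistinguishable in this assay when they carry this sulfonyl group. Nothing available explains why the change on the sulfonyl sulfur has this effect.

The compounds shown leave open which part of the entering group matters, something the same group with hydrogen in place of its chlorine could help to show. They also leave open how an open-chain amine such as 2-aminoethyl on the aromatic nitrogen would compare.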